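The source may report more compounds than this note shows. Statements on the series, on what has been measured and on what is new or still open speak of the compounds shown alone.

Of the compounds shown here, three sharing one core have been measured in a functional assay on BXPC-3 cells (Homo sapiens) for inhibition, read by MTT assay, with a stated time of 7 days; a lower number here means a stronger inhibitor, a higher number a weaker inhibitor. Compound 1 `O=C([C@@H]1CCCN(S(=O)(=O)c2ccc(S(=O)(=O)C3COC3)cc2)C1)N1CCC(F)(F)CC1` gives 361 nM, compound 2 `CCN(CC)C(=O)c1ccc(S(=O)(=O)N2CCC[C@@H](C(=O)N3CCC(F)(F)CC3)C2)cc1` gives 240 nM, and compound 3 `CCN(CC)S(=O)(=O)c1ccc(S(=O)(=O)N2CCC[C@@H](C(=O)N3CCC(F)(F)CC3)C2)cc1` gives 120 nM, the lowest of the three numbers. The step from compound 2 to compound 3 is a 2.0-fold lower number from compound 2 to compound 3 (0.30 log units; within the scatter), while the step from compound 1 to compound 3 is a 3.0-fold lower number from compound 1 to compound 3 (0.48 log units; beyond the scatter). Compound 4 `CC(C)CS(=O)(=O)c1ccc(S(=O)(=O)N2CCC[C@@H](C(=O)N3CCC(F)(F)CC3)C2)cc1` differs from compound 3 by isobutyl in place of diethylamino on a sulfonyl sulfur. For the measured compounds named here, the only step touching this position that lies beyond the scatter, a 3.0-fold lower number from compound 1 to compound 3 (0.48 log units; beyond the scatter), went from a carbon substituent to diethylamino; returning to a carbon substituent is therefore expected to move the number up modestly. For compound 4 the expected step is a 1.8-fold higher number from compound 3 to compound 4 (0.26 log units; within the scatter), giving an estimate of 220 nM within 90 nM to 550 nM.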

Compound 4, half-maximal inhibitory concentration: 311 nM
Beside the measured number, compound 4's estimate is 1.4-fold (0.15 log units) below it; low and high end bracket the measured number.
By their numbers in this assay, from the lowest: compounds 3, 2, 4 and 1 (each within the scatter of the next, the first and the last beyond it).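

Replacing diethylamino with isobutyl on the sulfonyl sulfur (a 2.6-fold higher number from compound 3 to compound 4 (0.41 log units; beyond the scatter)) shows that a second carbon substituent, not only oxetan-3-yl, goes with a higher number than diethylamino. Isobutyl and oxetan-3-yl cannot be told apart here (a 1.2-fold lower number from compound 1 to compound 4 (0.06 log units; within the scatter)), and neither can isobutylsulfonyl and diethylcarbamoyl (a 1.3-fold higher number from compound 2 to compound 4 (0.11 log units; within the scatter)). No measurement shown accounts for the difference between diethylamino and the carbon substituents. On these data alone, whether the lower number holds for other amines on the sulfonyl sulfur, such as dimethylamino or dipropylamino, remains open.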